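Replacing cyclopentyl with (pyridin-2-yl)methoxy on a carbonyl carbon

The source may report more compounds than this note shows. Statements on the series, on what has been measured and on what is new or still open speak of the compounds shown alone.

Measured compounds:
compound 1, `CNC(=O)c1cc(C)n(Cc2cc(Cl)ccc2OCc2ccccc2)n1`: > 3.7
compound 2, `Cc1cc(NC(=O)C2CCCC2)nn1Cc1cc(Cl)ccc1OCc1ccccc1`: 3.5

Of the compounds shown here, two have been measured in a physicochemical assay for lipophilicity, at pH 7.4; on this read-out higher numbers stand for higher lipophilicity and lower numbers for lower lipophilicity. For compound 1 the read-out is only a limit of the assay, > 3.7, and not a number. Among the compounds with values here, compound 2 gives 3.5, the only plain number here, so it stands alone with nothing measured to rank it against. Within the data shown here, the single measured step, a number at least 0.20 log units lower from compound 1 to compound 2 (that floor lies within the scatter), exchanges methylcarbamoyl for (cyclopentylcarbonyl)amino on an aromatic carbon; its floor lies within the scatter, and given the limit of > 3.7 in this assay, at which 1 of the 2 values shown sits, its true size stays unknown. Compound 3, `Cc1cc(NC(=O)OCc2ccccn2)nn1Cc1cc(Cl)ccc1OCc1ccccc1`, differs from compound 2 by (pyridin-2-yl)methoxy in place of cyclopentyl on a carbonyl carbon. Among the measured compounds shown here, no measured step shares this change, so the expectation rests on the structural change alone. Compound 3 is estimated at 2.8, within 2.2 to 3.4. That estimate means an expected step of a number 0.70 log units lower from compound 2 to compound 3 (beyond the scatter), downward and beyond the scatter.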

Compound 3, distribution coefficient: 3.1
The estimate for compound 3 lay 0.30 log units below the measured number; the range from low to high includes it.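

In this assay, within the data shown here, putting (pyridin-2-yl)methoxy in place of cyclopentyl on the carbonyl carbon gives a number 0.40 log units lower from compound 2 to compound 3 (beyond the scatter), the first step here with a full size and not only a floor, and the number goes down even though the entering group has 8 heavy atoms against 5, with 2 hydrogen-bond acceptors against 0. The replacement of methylcarbamoyl on the aromatic carbon by (((pyridin-2-yl)methoxy)carbonyl)amino reads a number at least 0.60 log units lower from compound 1 to compound 3 (beyond the scatter), a floor that now lies beyond the scatter. Compound 1 carries a limit of the assay and not a number, so the true size of that step stays unknown: the limit of > 3.7 in this assay, at which 1 of the 3 values shown sits.

Which part of the entering group goes with the lower number remains open. A benzyloxy group on the same carbonyl carbon, or a (pyridin-3-yl)methoxy group, would begin to separate the role of the ring nitrogen and its place from that of the oxygen.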